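A few compounds are considered here, and "the series" means these few. Any claim that something is new, unique, unknown or untested is made for them only; others in the source may bear on it.

Measured so far in a functional assay on the whole organism (strain Swiss) with Mus musculus as the target, in the maximal electroshock model, with a stated time of 0.25 h, at a dose of 300 mg/kg by the intraperitoneal route; on this read-out lower numbers stand for a weaker effect and higher numbers for a stronger effect at the one dose given:

compound 1, `CC(C(=O)N1CCN(c2ccc(C(F)(F)F)cc2)CC1)N1C(=O)CCC1=O`, gives 25%
compound 2, `CCC(C(=O)N1CCN(c2ccc(C(F)(F)F)cc2)CC1)N1C(=O)CCC1=O`, gives 25%
compound 3, `CCC(C(=O)N1CCN(c2cccc(C(F)(F)F)c2)CC1)N1C(=O)CCC1=O`, gives 75%

Compound 2 and compound 1 share one core and differ in a single place: hydrogen in place of methyl on a saturated chain carbon, two bonds along the chain from an amide-type nitrogen in a ring and a carbonyl carbon. On this pair the read-out moved no change at the digits printed from compound 2 to compound 1 (within the scatter), so shortening the chain at this carbon left the effect where it was.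

Compound 3 carries the other core. How the core of compound 3 differs from that of compound 2 is not broken down here. For the measured compounds named here, of the three numbers the one for compound 3 is the highest, and compound 1 and compound 2 each stand well below it.

Compound 4, `CC(C(=O)N1CCN(c2cccc(C(F)(F)F)c2)CC1)N1C(=O)CCC1=O`, is the counterpart of compound 3 on that core, reached by the same change seen between compound 2 and compound 1: hydrogen in place of methyl on a saturated chain carbon, two bonds along the chain from an amide-type nitrogen in a ring and a carbonyl carbon. The place of the change is worded identically for both pairs, so it is the same change, made this time on the core of compound 3.

Going by the values given here, the only precedent for this change, the step from compound 2 to compound 1, is flat. On that basis the step from compound 3 to compound 4 is expected to be small, a number 10 percentage points lower from compound 3 to compound 4 (within the scatter), though it rests on one pair on a different core. Among the compounds with values here, compound 4 is therefore expected to give about 65% in this assay, with a range from 25% to 100% allowing for the single precedent.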

Compound 4, a percentage reported as activity, at one dose (the size of the read-out at that dose, not a potency): 75%
Compound 4: the middle estimate sits 10 percentage points below what was measured; low and high end bracket the measured number.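

In this assay, the exchange of methyl for hydrogen on the saturated chain carbon, which shortens ethyl to methyl, gives no change at the digits printed from compound 3 to compound 4 (within the scatter). Set beside the earlier pair, the change reads the same on both cores, so for these two pairs the flat outcome carries from one core to the other: the same change on two cores in this assay, no change at the digits printed (within the scatter) from compound 2 to compound 1 and no change at the digits printed (within the scatter) from compound 3 to compound 4, 0 percentage points apart, within the scatter of two such steps. This does not establish that the chain at this carbon is irrelevant across the series, since the agreement rests on just two pairs, and a percentage at one dose and one stated time is not a potency, so any difference that would appear only at another dose or time remains out of view.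

The compounds shown span only ethyl and methyl at this chain carbon, leaving open whether a longer chain such as propyl or butyl, a branched chain such as isopropyl, or a phenyl group would stay equally flat on either core. As far as these compounds go, it also remains open whether a polar group at the same carbon, such as an amine or a carboxylic acid, would break the pattern seen with these two small alkyl groups.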